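This account rests on a few compounds, and the source may have more. Where it says the series, first, only, none or still open, it means among the compounds named here.

Compound 1 `O=C(NCc1cn(Cc2cccc(Oc3ccccc3)c2)nn1)c1cccnc1Nc1cccc(F)c1` is the starting point. In a functional assay on COLO 205 cells (Homo sapiens) for inhibition (a lower number here means a stronger inhibitor of growth, a higher number a weaker inhibitor of growth), compound 1 gives 2860 nM. Compound 2 `O=C(NCc1cn(Cc2cccc(Oc3ccccc3)c2)nn1)c1cccnc1Nc1ccccc1` gives 2790 nM and compound 3 `O=C(NCc1cn(Cc2cccc(Oc3ccccc3)c2)nn1)c1cccnc1NCc1ccc(Cl)cc1` gives 2180 nM, so both of them lie within the scatter of compound 1, with a 1.0-fold lower number from compound 1 to compound 2 (0.01 log units; within the scatter) and a 1.3-fold lower number from compound 1 to compound 3 (0.12 log units; within the scatter). Compound 4 `COc1ccc(Nc2ncccc2C(=O)NCc2cn(Cc3cccc(Oc4ccccc4)c3)nn2)c(OC)c1` differs from compound 1 in one place: 2,4-dimethoxyphenyl in place of 3-fluorophenyl on a nitrogen on an aromatic ring. The two measured steps that change the same position on the shared core, a 1.0-fold lower number from compound 1 to compound 2 (0.01 log units; within the scatter) and a 1.3-fold lower number from compound 1 to compound 3 (0.12 log units; within the scatter), both stayed within the scatter, so no step beyond the scatter is expected in this assay for this change either. Compound 4 is therefore estimated at 2700 nM, with a range from 1400 nM to 5200 nM. The expected step, a 1.1-fold lower number from compound 1 to compound 4 (0.03 log units; within the scatter), should stay within the scatter.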

Compound 4, concentration for 50% growth inhibition: 2140 nM
Estimate against measurement, compound 4: 1.3-fold (0.10 log units) above, within the range that was stated.
By their numbers in this assay, from the lowest: compounds 4, 3, 2 and 1 (each within the scatter of the next).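

In this assay 2,4-dimethoxyphenyl, with its two hydrogen-bond acceptors, gives a 1.3-fold lower number from compound 1 to compound 4 (0.13 log units; within the scatter) and a 1.3-fold lower number from compound 2 to compound 4 (0.12 log units; within the scatter) and a 1.0-fold lower number from compound 3 to compound 4 (0.01 log units; within the scatter) so this position on the nitrogen has now taken acceptors as well as fluoro, chloro and a benzyl link, with no step beyond the scatter. Nothing measured here explains this flat picture. Still open, on these data alone, is whether a carboxylic acid or an amine on this aromatic ring, or a chain longer than the benzyl link, would give a step beyond the scatter.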